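This account rests on a few compounds, and the source may have more. Where it says the series, first, only, none or still open, it means among the compounds named here.

For the measured compounds named here, compound 2, `Cc1ncc(CO)c2c(Nc3ccccn3)c(NCc3ccccc3)oc12`, is the one compound here that carries a number in a functional assay on HEK293 cells for agonist activity at Toll-like receptor 8 (Homo sapiens), read by reporter gene assay (on this read-out lower numbers stand for an effect already at smaller amounts and higher numbers for an effect only at larger amounts of compound), with a value of 4910 nM. Compound 1, `CCOC(=O)CNc1oc2c(C)ncc(CO)c2c1Nc1ccccn1`, a close relative with an ester-bearing side chain instead of the benzyl group, is recorded in this assay only as "not active" (no number reported), so no number stands beside it and nothing can be said about how far it lies from compound 2. Compound 3, `Cc1ncc(CO)c2c(Nc3ccccn3)c(NC(C)(C)CC(C)(C)C)oc12`, has not been measured in this assay. It differs from compound 2 in one place: 1,1,3,3-tetramethylbutyl in place of benzyl on a nitrogen on an aromatic ring. Going by the values given here, with only one measured value and no measured step between related compounds, there is nothing in these data to show which way such an exchange moves the read-out, so the expectation for compound 3 is a step from compound 2 of about a 1.2-fold higher number from compound 2 to compound 3 (0.09 log units; within the scatter), roughly within the scatter. Compound 3 is therefore estimated at 6000 nM, with a range from 1500 nM to 25000 nM.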

Compound 3, half-maximal effective concentration: "not active" (no number reported)
No number was reported for compound 3, so the estimate cannot be set against anything.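

Compound 3 carries no number in this assay, and with compound 2 as the only compound holding a value, no step between compound 2 and compound 3 can be read; nothing shown here explains the result. The compounds shown leave open which groups on that nitrogen give measurable activity.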